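A few compounds are considered here, and "the series" means these few. Any claim that something is new, unique, unknown or untested is made for them only; others in the source may bear on it.

In a functional assay on NCI-H1299 cells (Homo sapiens) for inhibition, read by CCK-8 assay, with a stated time of 72 h, tested at 10 uM (a higher number here means more inhibition of growth at the concentration tested, a lower number less inhibition of growth), compound 3 (`CN(C)C(=O)c1cc2cnc(Nc3ccc(NC(=O)C4(C(=O)Nc5cccc(F)c5)CC4)cc3)nc2n1C1CCCC1`) gives 87%. Compound 1 (`CN(C)C(=O)c1cc2cnc(Nc3ccc(NC(=O)C4(C(=O)Nc5ccc(F)cc5)CC4)cc3)nc2n1C1CCCC1`) gives 90.8% and compound 2 (`CN(C)C(=O)c1cc2cnc(Nc3ccc(N)cn3)nc2n1C1CCCC1`) gives 82.1%, both within the usual scatter of compound 3, so these numbers do not rank the three. Compound 4 (`CN(C)C(=O)c1cc2cnc(Nc3ccc(NC(=O)C4(C(=O)Nc5ccc(Br)cc5)CC4)cc3)nc2n1C1CCCC1`) differs from compound 3 in one place: 4-bromophenyl in place of 3-fluorophenyl on an amide-type nitrogen, with 4-bromophenyl in place of 3-fluorophenyl on an amide-type nitrogen. One measured step changes the group at this same place: a number 3.8 percentage points lower from compound 1 to compound 3 (within the scatter), with 3-fluorophenyl in place of 4-fluorophenyl. Among the measured compounds shown here, no measured compound carries bromine, so this guide is only indirect. The expected result in this assay is a number 1 percentage points higher from compound 3 to compound 4 (within the scatter), a step no larger than the scatter. Compound 4 is estimated at 88%, with an expected range of 78% to 96%.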

Compound 4, percent growth inhibition at one concentration: 76.9%
For compound 4 the middle estimate is 11.1 percentage points above the measured one; the measured number lies below the stated range.
By their numbers in this assay, from the lowest: compounds 4, 2, 3 and 1 (each within the scatter of the next, the first and the last beyond it).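

In this assay, this place on the amide-type nitrogen now shows a step beyond the scatter: 4-bromophenyl in place of 3-fluorophenyl goes with a number 10.1 percentage points lower from compound 3 to compound 4 (beyond the scatter), and bromo in place of fluoro on the aromatic carbon, with nothing else changed, goes with a number 13.9 percentage points lower from compound 1 to compound 4 (beyond the scatter). The two fluorophenyl compounds alone had shown no such step, so the identity of the halogen matters here in a way they could not reveal. Nothing measured here gives a cause for this drop.

Still open, on these data alone, is whether plain phenyl, or a chloro or amine group on this ring, would stay with the fluoro compounds or fall with compound 4.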